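Methyl for methoxy on the amide aryl ring

A few compounds are considered here, and "the series" means these few. Any claim that something is new, unique, unknown or untested is made for them only; others in the source may bear on it.

The three measured compounds share one core and differ only in the group attached to the carbonyl carbon. Compound 1 `COc1cccc(C(=O)Nc2cc(Sc3ncn[nH]3)c(O)c3ccccc23)c1` was tested in an assay on isolated protein for inhibition of RAC-alpha serine/threonine-protein kinase (Homo sapiens), read by fluorescence, with a stated time of 30 min, tested at 10 uM (a lower number here means less inhibition, a higher number more inhibition at the concentration tested (going by the name of the read-out)), and gives 19.4%. Compound 2 `O=C(/C=C/c1ccc([N+](=O)[O-])cc1)Nc1cc(Sc2ncn[nH]2)c(O)c2ccccc12` gives 40.6%, and compound 3 `O=C(Nc1cc(Sc2ncn[nH]2)c(O)c2ccccc12)c1ccc(Cl)cc1` gives 50.1%. Compound 1 thus stands lowest of the three, with compound 2 nearest and compound 3 furthest, both beyond the scatter.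

Among the compounds with values here, the one step that can be traced to a single change is a number 30.7 percentage points higher from compound 1 to compound 3 (beyond the scatter), where 4-chlorophenyl in place of 3-methoxyphenyl on the carbonyl carbon raised inhibition markedly. Compound 4 `Cc1cccc(C(=O)Nc2cc(Sc3ncn[nH]3)c(O)c3ccccc23)c1` is the next compound to be measured. It differs from compound 1 by methyl in place of methoxy on an aromatic carbon, a change at the same ring that was altered on the way to compound 3, though much smaller in reach than that one.

Within the data shown here, because the only informative step is a number 30.7 percentage points higher from compound 1 to compound 3 (beyond the scatter) and it involved a different position and a different group, the direction for compound 4 is uncertain; a change smaller than that step, or none beyond the scatter, is expected. Compound 4 is estimated at 26%, within 10% to 45%, so the expected step is a number 6.6 percentage points higher from compound 1 to compound 4 (within the scatter).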

Compound 4, a percentage reported as inhibition, at one concentration (the size of the read-out at that concentration, not a potency): 20.2%
Compound 4: middle estimate off by 5.8 percentage points, on the high side; low and high end bracket the measured number.
By their numbers in this assay, from the lowest: compounds 1 and 4 (each within the scatter of the next); then compounds 2 and 3 (each within the scatter of the next).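

The change from methoxy to methyl gives a number 0.8 percentage points higher from compound 1 to compound 4 (within the scatter) in this assay, and at this place on the ring compound 1 and compound 4 cannot be told apart. Replacing the 3-methoxyphenyl group with 3-methylphenyl therefore does not reproduce the level of compound 3, and a number 29.9 percentage points lower from compound 3 to compound 4 (beyond the scatter) shows that compound 4 also stands well apart from that compound, although this step alters both the group and its place on the ring. No measurement offered here explains either step.

The compounds shown do not settle whether the higher number of compound 3 depends on the chlorine itself or on where the group sits, since no compound here separates those two features. As far as these compounds go, it also remains open whether this place on the ring responds to any group at all, as methoxy and methyl are the only two compared there, and an amine, a carboxylic acid or a longer chain in the same place could still give a different number.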